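A few compounds are considered here, and "the series" means these few. Any claim that something is new, unique, unknown or untested is made for them only; others in the source may bear on it.

Compound 1 `COc1ccc(/C=C\c2cc(OC)c(OC)c(OC)c2)cc1OCc1ccc(CN2CC[C@H](C(=O)O)C2)cc1`: > 10000 nM, a limit of the assay
Compound 2 `COc1ccc(/C=C\c2cc(OC)c(OC)c(OC)c2)cc1OCc1ccc(CNCCN(C)C)cc1`: 9400 nM

Within the data shown here, in a functional assay on HeLa cells (Homo sapiens) for antiproliferative activity, read by CCK-8 assay, with a stated time of 48 h (a higher number here means a weaker inhibitor, a lower number a stronger inhibitor), compound 2 gives 9400 nM, the only actual number so far. For compound 1, the entry of > 10000 nM is a limit and not a number.

Compound 3 `COc1ccc(/C=C\c2cc(OC)c(OC)c(OC)c2)cc1OCc1ccc(CN2CC[C@@H](O)C2)cc1` has not yet been measured. It differs from compound 2 on a saturated chain carbon bound to an aromatic carbon, where 3-hydroxypyrrolidin-1-yl replaces (2-(dimethylamino)ethyl)amino: 3-hydroxypyrrolidin-1-yl in place of (2-(dimethylamino)ethyl)amino on a saturated chain carbon bound to an aromatic carbon.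

Among the measured compounds shown here, one measured step bears on this place: an at least 1.0-fold lower number from compound 1 to compound 2 (0.02 log units; that floor lies within the scatter). It starts from a limit (the limit of > 10000 nM in this assay, at which 1 of the 2 values shown sits), so it gives only a floor, and that floor lies within the scatter. It therefore offers no ground for expecting a shift in either direction. The expectation rests on compound 2 at 9400 nM, and no change beyond the scatter is expected in this assay. A result reported only as a limit remains possible. The expected size of the change is a 1.2-fold lower number from compound 2 to compound 3 (0.07 log units; within the scatter). For compound 3, the estimated value is 8000 nM, with an expected range from 2500 nM to 20000 nM.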

Compound 3, half-maximal inhibitory concentration: > 10000 nM
Compound 3 ended at the assay's limit; the forecaster's own chance of this, stated with the estimate: 40%; at least 1.2-fold (0.09 log units) between middle value and limit.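

In this assay, putting 3-hydroxypyrrolidin-1-yl in place of (2-(dimethylamino)ethyl)amino on a saturated chain carbon bound to an aromatic carbon gives an at least 1.0-fold higher number from compound 2 to compound 3 (0.02 log units; that floor lies within the scatter). This is a floor and not a measured size, so it does not establish a real loss of activity on leaving the open chain for the ring. What is new is that a second five-membered ring at this place, now bearing a hydroxyl group and not a carboxylic acid, also ends without an actual number, and the step from compound 1 to compound 3 cannot be read: the limit of > 10000 nM in this assay, at which 2 of the 3 values shown sit.

Of the three groups shown, only the (2-(dimethylamino)ethyl)amino group of compound 2 gives an actual number, and no compound shows how much activity this place can support, if any, in the range the assay can resolve. From the compounds shown here alone, what a morpholine ring, a primary amine or a longer chain ending in a dimethylamino group would do here stays open, as does the effect of reversing the defined stereocentre of the 3-hydroxypyrrolidin-1-yl group.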